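Adding a prenyl ether to the hydroxy compound 1

The compounds below may be only part of what the source reports. "The series", "measured", "known", "first", "only" and "open" are said of these compounds alone.

compound 1 `COc1cc(O)c(C(=O)/C=C/c2cccc(OC)c2OC)c(OC)c1` gives 3500 nM
compound 2 `COc1cc(OC)c(C(=O)/C=C/c2ccc(Br)cc2)c(OCC=C(C)C)c1` gives 2100 nM
compound 3 `COc1cccc(/C=C/C(=O)c2c(OC)cc(OC)cc2OCC=C(C)C)c1` gives 7700 nM

In a functional assay on HCT-116 cells (Homo sapiens) for antiproliferative activity, read by sulforhodamine B assay, with a stated time of 48 h (a lower number here means a stronger inhibitor, a higher number a weaker inhibitor), compound 1 stands at 3500 nM and lies within the scatter of compound 2 but beyond the scatter of compound 3, on the lower side. The change to compound 4 `COc1cc(OC)c(C(=O)/C=C/c2cccc(OC)c2OC)c(OCC=C(C)C)c1` is 3-methylbut-2-en-1-yl in place of hydrogen on an oxygen on an aromatic ring and reads hydroxy to (3-methylbut-2-en-1-yl)oxy. Within the data shown here, no measured step makes this change. Among the measured compounds shown here, the only measured step is a 3.7-fold higher number from compound 2 to compound 3 (0.56 log units; beyond the scatter) and it swaps a different group, with (3-methylbut-2-en-1-yl)oxy present on both sides. Compound 2 at 2100 nM and compound 3 at 7700 nM span the value of compound 1, so no step beyond the scatter is expected in this assay in either direction. The expected size is a 1.1-fold higher number from compound 1 to compound 4 (0.06 log units; within the scatter) and this stays within the scatter. Compound 4 is estimated at 4000 nM with 1500 nM to 10000 nM as the expected range.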

Compound 4, half-maximal inhibitory concentration: 11700 nM
Compound 4: middle estimate off by 2.9-fold (0.47 log units), on the low side; the whole stated range lies below it.
By their numbers in this assay, from the lowest: compounds 2 and 1 (each within the scatter of the next); then compounds 3 and 4 (each within the scatter of the next).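

Putting 3-methylbut-2-en-1-yl on the oxygen in place of hydrogen weakens the compound in this assay, with a 3.3-fold higher number from compound 1 to compound 4 (0.52 log units; beyond the scatter), so this change is not neutral on this aromatic ring. Methoxy in place of hydrogen on an aromatic carbon makes no clear difference among the prenyl ethers, with a 1.5-fold higher number from compound 3 to compound 4 (0.18 log units; within the scatter). With the prenyl ether held fixed, 2,3-dimethoxyphenyl in place of 4-bromophenyl gives a 5.6-fold higher number from compound 2 to compound 4 (0.75 log units; beyond the scatter). Nothing shown explains the loss. On these data alone, it remains open whether a methoxy or an allyloxy group on that oxygen would weaken the compound likewise.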